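The source may report more compounds than this note shows. Statements on the series, on what has been measured and on what is new or still open speak of the compounds shown alone.

Compound 1 `CCn1c(C(=O)N[C@@H](C)CO)ccc1C(CC)(CC)c1ccc(OCS(=O)(=O)c2ccccc2)c(C)c1` is the reference point of this small set. In a functional assay on MCF7 cells (Homo sapiens) for antiproliferative activity, read by MTT assay, with a stated time of 24 h (a lower number here means a stronger inhibitor, a higher number a weaker inhibitor), compound 1 gives 10800 nM, the lowest of the three numbers recorded. In this assay compound 2 `CCn1c(C(=O)NCCO)ccc1C(CC)(CC)c1ccc(OCS(=O)(=O)c2ccccc2)c(C)c1` gives 15500 nM, and compound 3 `CCn1c(C(=O)N[C@@H](CO)CCCO)ccc1C(CC)(CC)c1ccc(OCS(=O)(=O)c2ccccc2)c(C)c1` gives 29600 nM. The steps among them are small: a 1.4-fold higher number from compound 1 to compound 2 (0.16 log units; within the scatter), a 1.9-fold higher number from compound 2 to compound 3 (0.28 log units; within the scatter), and a 2.7-fold higher number from compound 1 to compound 3 (0.44 log units; beyond the scatter), the last being the only one that lies beyond the scatter.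

Compound 4 `CCn1c(C(=O)N[C@H](CC(=O)O)C(=O)O)ccc1C(CC)(CC)c1ccc(OCS(=O)(=O)c2ccccc2)c(C)c1` has not yet been measured. It differs from compound 1 on the amide-type nitrogen whose other neighbour is the carbonyl carbon: 1,2-dicarboxyethyl in place of 1-(hydroxymethyl)ethyl on an amide-type nitrogen. Going by the values given here, the step that bears most directly on this is the one from compound 1 to compound 3, where a group of 7 heavy atoms took the place of a group of 4 heavy atoms on the same nitrogen and the number rose modestly. Among the compounds with values here, the change to compound 4 is larger still, as the counted difference shows, and no measured compound carries a carboxylic acid. Compound 4 is therefore expected to give a higher number than compound 1, with a step estimated at a 2.6-fold higher number from compound 1 to compound 4 (0.41 log units; beyond the scatter). The estimate for compound 4 in this assay is 28000 nM, within an expected range of 12000 nM to 65000 nM.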

Compound 4, half-maximal inhibitory concentration: > 50000 nM
Compound 4 ended at the assay's limit (the forecaster's own chance of this, stated with the estimate: 25%); at least 1.7-fold (0.25 log units) between middle value and limit.
By their numbers in this assay, from the lowest: compounds 1, 2 and 3 (each within the scatter of the next, the first and the last beyond it). At a limit, above all of these: compound 4.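

In this assay, compound 4 is the only compound shown whose reading is a limit of the assay and not a number: the limit of > 50000 nM in this assay, at which 1 of the 4 values shown sits.

Putting 1,2-dicarboxyethyl on the amide-type nitrogen brings the first carboxylic acids to this position, and the change gives an at least 4.6-fold higher number from compound 1 to compound 4 (0.66 log units; beyond the scatter) and an at least 3.2-fold higher number from compound 2 to compound 4 (0.50 log units; beyond the scatter), so even these floors lie beyond the scatter, whereas the step between the two smaller hydroxyl-bearing chains does not. The remaining comparison, an at least 1.6-fold higher number from compound 3 to compound 4 (0.22 log units; that floor lies within the scatter), does not settle how far apart these two chains lie, and the set therefore does not show that the acid-bearing chain differs from the larger of the hydroxyl-bearing chains.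

The compounds shown do not separate the effect of the two carboxylic acids taken together from that of either one alone, and a chain with a single carboxylic acid, a methyl ester of the acids or a primary amine at this position would bear on that question. From the compounds shown here alone, how far the true value of compound 4 lies past its limit also stays unknown, so the full size of these steps remains open.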